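The source may report more compounds than this note shows. Statements on the series, on what has been measured and on what is new or still open speak of the compounds shown alone.

Measured so far in a functional assay on HCC 2998 cells (Homo sapiens) for inhibition, read by sulforhodamine B assay, with a stated time of 48 h, tested at 0.1 uM; on this read-out higher numbers stand for a weaker effect at the one concentration tested and lower numbers for a stronger effect:
compound 1 `O=C(Nc1cccc(-n2cc(-c3ccncc3)c(-c3cc(O)cc(Cl)c3)n2)c1)Nc1ccc(Cl)c(C(F)(F)F)c1` — 97%
compound 2 `COc1cc(Cl)cc(-c2nn(-c3cccc(NC(=O)Nc4ccc(Cl)c(C(F)(F)F)c4)c3)cc2-c2ccncc2)c1` — 94%

Among the compounds with values here, compound 2 stands together with compound 1; the single step recorded, a number 3 percentage points lower from compound 1 to compound 2 (within the scatter), is within the scatter, so the two numbers cannot be told apart, and both point to only a slight effect at the tested concentration.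

Compound 3 `COc1cc(Cl)cc(-c2nn(-c3cccc(NC(=O)c4cccc(C(F)(F)F)c4)c3)cc2-c2ccncc2)c1` is not yet measured. It differs from compound 2 by 3-(trifluoromethyl)phenyl in place of (4-chloro-3-(trifluoromethyl)phenyl)amino on a carbonyl carbon. Within the data shown here, no measured step touches this part of the structure; the only recorded step concerns the methyl on the oxygen of the aromatic ring and says nothing about the (4-chloro-3-(trifluoromethyl)phenyl)amino group or the carbonyl carbon. With both measured compounds giving high numbers, the expectation is a step of a number 3 percentage points higher from compound 2 to compound 3 (within the scatter), that is, no change beyond the scatter. Compound 3 is therefore estimated at 97%, with a range of 86% to 108%.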

Compound 3, a percentage reported as activity, at one concentration (the size of the read-out at that concentration, not a potency): 104%
The estimate for compound 3 lay 7 percentage points below the measured number; the range from low to high includes it.
By their numbers in this assay, from the lowest: compounds 2, 1 and 3 (each within the scatter of the next).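

Within the data shown here, this is the first reading at this position: in this assay, 3-(trifluoromethyl)phenyl in place of (4-chloro-3-(trifluoromethyl)phenyl)amino on the carbonyl carbon gives a number 10 percentage points higher from compound 2 to compound 3 (within the scatter). At this one concentration, the read-out therefore does not separate the two groups, even though they differ in the chlorine, the amino nitrogen and its hydrogen-bond donor; all three compounds show little or no effect, so the step shows no gain and no measurable loss. No measurement available here bears on why the two groups read alike.

Going by these compounds, whether any group on this carbonyl carbon can produce a clear effect remains open, and a result this close to the top of the read-out cannot rank these groups. A piperidine or a butyl chain on the carbonyl carbon, in place of 3-(trifluoromethyl)phenyl, would test the position with a different kind of group.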